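A few compounds are considered here, and "the series" means these few. Any claim that something is new, unique, unknown or untested is made for them only; others in the source may bear on it.

Measured so far:
compound 1 `COc1cc(C)cc(-c2c(-c3ccnc(-c4ccc(C(C)=O)cc4)c3)cnn2CC#N)c1` — > 100000 nM
compound 2 `Cc1cc(O)cc(-c2nn(CC#N)cc2-c2ccnc(-c3ccc(Oc4ccccc4)cc3)c2)c1` — 4020 nM

In a functional assay on SN12C cells (Homo sapiens) for inhibition, read by sulforhodamine B assay, with a stated time of 48 h (a higher number here means a weaker inhibitor of growth, a lower number a stronger inhibitor of growth), compound 1 gives only a limit, > 100000 nM, and no number. That is the limit of > 100000 nM in this assay, at which 1 of the 2 values shown sits. Compound 2 differs from compound 1 in two places. In this assay compound 2 gives 4020 nM. Within the data shown here, with no single-point step between them, the two values show only that one compound is read as a number and the other is not.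

Compound 3 `COc1cc(C)cc(-c2c(-c3ccnc(-c4ccc(N(C)C)cc4)c3)cnn2CC#N)c1` is not yet measured. It differs from compound 1 by dimethylamino in place of acetyl on an aromatic carbon. Among the measured compounds shown here, with compound 1 standing at a limit, no measured step tells how large a change this swap brings. A gain in growth inhibition of about an at least 3.3-fold lower number from compound 1 to compound 3 (0.52 log units; beyond the scatter) is expected, with wide uncertainty. For compound 3 the expected value in this assay is 30000 nM, in the range 5000 nM to 150000 nM.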

Compound 3, concentration for total growth inhibition: > 100000 nM
Compound 3: a limit, no number; the forecaster's own chance of this, stated with the estimate: 40%; middle value at least 3.3-fold (0.52 log units) away from the limit.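

No step from compound 1 to compound 3 can be read in this assay, because each of the two compounds gives only a limit and no number: the limit of > 100000 nM in this assay, at which 2 of the 3 values shown sit.

As far as these compounds go, whether dimethylamino in place of acetyl on an aromatic carbon changes growth inhibition at all, and by how much, stays open.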